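The source may hold more compounds than are shown below. What is called first, only, known or untested is meant among the compounds shown, and "the series" means these compounds.

Working notes on the anilide series measured in an in vitro assay on Sf21 cells for inhibition of high affinity 3',5'-cyclic-AMP phosphodiesterase 7A (Homo sapiens), read by scintillation proximity assay, with a stated time of 30 min; on this read-out lower numbers stand for stronger inhibition and higher numbers for weaker inhibition.

Compound 1 `CCN(CC)c1ccc(NC(=O)c2cn(Cc3c(F)cccc3F)c3ccc(=O)[nH]c3c2=O)cc1` carries a diethylamino group on the aromatic ring of the anilide and in this assay gives 46 nM. Compound 2 `N#Cc1ccc(NC(=O)c2cn(Cc3c(F)cccc3F)c3ccc(=O)[nH]c3c2=O)cc1` has the same core with a cyano group in its place; in this assay compound 2 gives 96 nM. Within the data shown here, the one step between measured compounds, cyano in place of diethylamino on an aromatic carbon, reads a 2.1-fold higher number from compound 1 to compound 2 (0.32 log units; beyond the scatter). Among the measured compounds shown here, compound 2 therefore stands with the highest of the two numbers so far, its nearest neighbour being compound 1.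

Compound 3 `N#Cc1cccc(NC(=O)c2cn(Cc3c(F)cccc3F)c3ccc(=O)[nH]c3c2=O)c1` has not yet been measured. Its difference from compound 2 is 3-cyanophenyl in place of 4-cyanophenyl on an amide-type nitrogen: the same atoms, joined differently. For the measured compounds named here, no measured step moves a substituent from one position of the anilide ring to another, so the step from compound 1 to compound 2 bears on it only in that a change at this ring gave a modest shift; it gives no direction for a positional change. The expectation for compound 3 is therefore a step of a 1.0-fold higher number from compound 2 to compound 3 (0.02 log units; within the scatter), none beyond the scatter, and compound 3 is estimated at 100 nM, within a range from 40 nM to 250 nM.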

Compound 3, half-maximal inhibitory concentration: 1070 nM
Compound 3: the middle estimate sits 11-fold (1.03 log units) below what was measured, and the stated range ends below it.
By their numbers in this assay, from the lowest: compound 1; then compound 2; then compound 3.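

In this assay, the same atoms joined differently give an 11-fold higher number from compound 2 to compound 3 (1.05 log units; beyond the scatter), so the point at which the nitrile is attached to the anilide ring carries a large effect, whereas the earlier exchange of one group for another gave only a modest 2.1-fold higher number from compound 1 to compound 2 (0.32 log units; beyond the scatter). The series now also spans a 23-fold higher number from compound 1 to compound 3 (1.37 log units; beyond the scatter), and compound 3 has the highest number of the three, with its steps to both other compounds beyond the scatter, so 3-cyanophenyl on the amide-type nitrogen is the least favourable of the three groups in this read-out. No measurement at hand bears on why the position of the nitrile matters so much.

The compounds shown leave open whether the change from a 4-substituted to a 3-substituted phenyl has a comparable effect with other groups, such as diethylamino, a primary amine or a carboxylic acid, or whether it is particular to the nitrile. They also leave open how either cyanophenyl compares with a plain phenyl, so it remains unclear whether 4-cyanophenyl favours inhibition, 3-cyanophenyl disfavours it, or both.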